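This account rests on a few compounds, and the source may have more. Where it says the series, first, only, none or still open, it means among the compounds named here.

Measured so far:
- compound 1 `Cc1cc(=O)c(O)c(CN2CCCCC2)n1C`: 7.07
- compound 2 `O=c1cc(CN2CCCCC2)n(CCN2CCCCC2)cc1O`: 7.58

In a physicochemical assay for acid dissociation, using potentiometric titration, compound 2 gives the higher of the two numbers, 7.58, and the gap to compound 1 lies beyond the scatter. Compound 3 `Cn1cc(O)c(=O)cc1CN1CCCCC1` has not yet been measured. It differs from compound 2 in one place: hydrogen in place of (piperidin-1-yl)methyl on a saturated chain carbon bound to an aromatic nitrogen. Going by the values given here, no measured pair shows this change, so the guide is thin. Compound 1, at 7.07, is the only other reference, so a modest fall, just beyond the scatter, is expected. The expected step is a number 0.38 log units lower from compound 2 to compound 3 (beyond the scatter). For compound 3 the estimated value is 7.2, with an expected range from 6.7 to 7.8.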

Compound 3, acid dissociation constant: 6.74
Beside the measured number, compound 3's estimate is 0.46 log units above it, within the range that was stated.
By their numbers in this assay, from the lowest: compound 3; then compound 1; then compound 2.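

Swapping (piperidin-1-yl)methyl for hydrogen on a saturated chain carbon bound to an aromatic nitrogen gives, in this assay, a number 0.84 log units lower from compound 2 to compound 3 (beyond the scatter), the first step read from a single change. It shows that this place is not neutral for the read-out: with hydrogen there, the proton is given up more readily. Nothing available explains the shift. Still open, on these data alone, is whether a shorter amine, such as dimethylamino, or a carboxylic acid on that same carbon would move the number as far, or only part of the way.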